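The source may report more compounds than this note shows. Statements on the series, on what has been measured and on what is new or still open speak of the compounds shown alone.

Measured compounds:
compound 1 `Cc1cc(N2CCCC2)c2ncc(CSCCc3ccccc3)n2c1`: > 100 ug/mL
compound 2 `Cc1cc(N2CCCC2)c2ncc(CSCc3ccccc3)n2c1`: >= 20 ug/mL

In an ADME assay on HEL cells (Homo sapiens) for cytotoxicity, with a stated time of 3 days (a higher number here means that more compound is tolerated, a lower number that less compound is tolerated), compound 1 gives > 100 ug/mL, which is a limit of the assay and not a number; compound 1 sits at the limit of > 100 ug/mL in this assay, at which 1 of the 2 values shown sits. Compound 2 gives >= 20 ug/mL, likewise a limit; compound 2 sits at the limit of >= 20 ug/mL in this assay, at which 1 of the 2 values shown sits. Within the data shown here, the step that the two limits leave unreadable from compound 1 to compound 2, phenyl in place of benzyl on a saturated chain carbon bound to a sulfur, therefore cannot be read, and it is the only measured step available.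

Compound 3 `Cc1cc(-n2cccc2)c2ncc(CSCCc3ccccc3)n2c1` differs from compound 1 by 1H-pyrrol-1-yl in place of pyrrolidin-1-yl on an aromatic carbon. Among the measured compounds shown here, no measured step covers this change, and the one step that exists is unreadable, so nothing here supports a shift beyond the scatter in this assay in either direction. Compound 3 is accordingly expected to give about 100 ug/mL, with a range from 35 ug/mL to 100 ug/mL, which means an expected step of a number no higher from compound 1 to compound 3 (the limit leaves the size open) from compound 1.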

Compound 3, minimum cytotoxic concentration: 100 ug/mL
Compound 3: the middle estimate sits on the measured number at the digits printed; low and high end bracket the measured number.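

With compound 3, the position ortho to a fused ring gains its first actual number in this assay: compound 3 gives 100 ug/mL, so a cytotoxic concentration is now measured with 1H-pyrrol-1-yl at this aromatic carbon. Compound 1, with pyrrolidin-1-yl in the same place, remains a limit of the assay and not a number: the limit of > 100 ug/mL in this assay, at which 1 of the 3 values shown sits. The change itself reads only as a number no higher from compound 1 to compound 3 (the limit leaves the size open), and neither step shown can be read for size.

Going by these compounds, whether the swap from pyrrolidin-1-yl to 1H-pyrrol-1-yl would move the value beyond the usual scatter therefore stays open. Also open, on these data alone, is how this assay would respond to a morpholin-4-yl group or an open-chain dimethylamino group at this position, or to a longer chain on the sulfur.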